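Swapping the Amine on a Thiocarbonyl Carbon

A few compounds are considered here, and "the series" means these few. Any claim that something is new, unique, unknown or untested is made for them only; others in the source may bear on it.

Measured so far:
- compound 1, `COc1ccc2occ(CSC(=S)N(C(C)C)C(C)C)c(=O)c2c1`, 4700 nM
- compound 2, `Cc1ccc2c(=O)c(CSC(=S)N(C(C)C)C(C)C)coc2c1`, 6300 nM
- compound 3, `O=c1c(CSC(=S)N2CCOCC2)coc2ccccc12`, 12000 nM

These three were tested in a functional assay on LM7 cells (Homo sapiens) for antiproliferative activity, read by MTT assay, with a stated time of 72 h; a lower number here means a stronger inhibitor, a higher number a weaker inhibitor. Compound 3 shows the highest number of the three. Its nearest neighbour is compound 2, whose number lies within the usual scatter of compound 3; compound 1 sits further away, beyond the scatter. Compound 3 is therefore not clearly weaker than compound 2, but it is clearly weaker than compound 1.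

The next compound, compound 4, `CC(C)N(C(=S)SCc1coc2ccccc2c1=O)C(C)C`, differs from compound 3 in one place: diisopropylamino in place of morpholin-4-yl on a thiocarbonyl carbon. For the measured compounds named here, no pair of measured compounds differs in exactly this way, so the size of this step has not been observed directly. Both compound 1 and compound 2 carry the diisopropylamino group and give lower numbers than compound 3, though each also differs from compound 3 on the shared core. On that basis a moderate step toward a lower number is expected from compound 3 to compound 4, roughly at the edge of the scatter, a 2.0-fold lower number from compound 3 to compound 4 (0.30 log units; within the scatter). Compound 4 is expected to give about 6000 nM in this assay, plausibly between 2500 nM and 14000 nM.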

Compound 4, half-maximal inhibitory concentration: 21900 nM
Compound 4: middle estimate off by 3.7-fold (0.56 log units), on the low side, and the stated range ends below it.
By their numbers in this assay, from the lowest: compounds 1, 2, 3 and 4 (each within the scatter of the next, the first and the last beyond it).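

In this assay, diisopropylamino in place of morpholin-4-yl on a thiocarbonyl carbon gives a 1.8-fold higher number from compound 3 to compound 4 (0.26 log units; within the scatter), so on this unsubstituted core the two amines cannot be told apart. With diisopropylamino held fixed, hydrogen in place of methyl on an aromatic carbon gives a 3.5-fold higher number from compound 2 to compound 4 (0.54 log units; beyond the scatter), and hydrogen in place of methoxy on an aromatic carbon gives a 4.7-fold higher number from compound 1 to compound 4 (0.67 log units; beyond the scatter), so the lower numbers of compound 1 and compound 2 go with these aromatic substituents rather than with the amine. No measurement at hand explains these steps.

As far as these compounds go, whether dimethylamino or piperidin-1-yl on the thiocarbonyl carbon would move the number beyond the scatter remains open. So does whether morpholin-4-yl would behave the same alongside a methyl or methoxy group, or whether chloro on an aromatic carbon would match them.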